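The source may hold more compounds than are shown below. What is called first, only, known or untested is meant among the compounds shown, and "the series" means these compounds.

Measured so far in an ADME assay on HEK293 cells (Homo sapiens) for cytotoxicity, read by MTT assay, with a stated time of 48 h (a higher number here means a weaker inhibitor, a lower number a stronger inhibitor), are these compounds:
- compound 1 `Cc1nc(-c2ccc(Cl)cc2)sc1C(=O)CSc1nc(-c2ccccc2)c(C#N)c(=O)[nH]1` gives "not determined" (no result reported)
- compound 2 `COc1cccc(-c2nc(SCC(=O)c3sc(-c4ccccc4)nc3C)[nH]c(=O)c2C#N)c1` gives 90200 nM

Compound 1 has no single number in this assay and therefore offers no starting value for the step considered here. For the measured compounds named here, the only number is that of compound 2 at 90200 nM and it serves as a rough anchor. The change to compound 3 `Cc1nc(-c2ccc(Cl)cc2)sc1C(=O)CSc1nc(-c2ccc(Cl)c(Cl)c2)c(C#N)c(=O)[nH]1` reads 3,4-dichlorophenyl in place of phenyl on an aromatic carbon and puts 3,4-dichlorophenyl in place of phenyl on an aromatic carbon, ortho to a cyano group. Going by the values given here, no measured pair shows what this change does. A modest step towards a lower number in this assay is expected, not far beyond the usual scatter, and this remains an expectation without a direct precedent. For compound 3 the estimated value is 45000 nM with an expected range of 12000 nM to 130000 nM in this assay.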

Compound 3, half-maximal inhibitory concentration: 46900 nM
Beside the measured number, compound 3's estimate is 1.0-fold (0.02 log units) below it; measured number inside the range.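

In this assay, for the compounds shown here, compound 1 gives "not determined" (no result reported) and so no step from it to compound 3 can be read. On these data alone, what 3,4-dichlorophenyl in place of phenyl does on its own stays open. No measured evidence bears on this result.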